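A few compounds are considered here, and "the series" means these few. Any claim that something is new, unique, unknown or untested is made for them only; others in the source may bear on it.

Measured compounds in a functional assay on RAW264.7 cells (Mus musculus) for inhibition, read by fluorescence, with stated times of 1 h, 24 h and 30 min; on this read-out higher numbers stand for weaker inhibition and lower numbers for stronger inhibition:

- compound 1 `O=C(/C=C/c1ccc(C(F)(F)F)cc1)c1ccccc1O`: > 10000 nM, a limit of the assay, not a number
- compound 2 `O=C(/C=C/c1ccc(C(F)(F)F)cc1)c1cccc(O)c1`: > 10000 nM, likewise a limit of the assay
- compound 3 `O=C(/C=C/c1ccccc1OC(F)(F)F)c1ccccc1O`: the entry reads "not determined" (no result reported)

Compound 1 and compound 2 share one core and differ by 3-hydroxyphenyl in place of 2-hydroxyphenyl on a carbonyl carbon. The step that the two limits leave unreadable from compound 1 to compound 2 cannot be read because of the limit of > 10000 nM in this assay, at which 2 of the 3 values shown sit. Compound 3 carries a different core; how the two cores differ is not broken down here.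

Compound 4 `O=C(/C=C/c1ccccc1OC(F)(F)F)c1cccc(O)c1` is still to be measured in this assay. It differs from compound 3 by 3-hydroxyphenyl in place of 2-hydroxyphenyl on a carbonyl carbon, the same change that leads from compound 1 to compound 2, the place lines being identical word for word. Among the measured compounds shown here, for compound 3 no number is available, so the step to compound 4 cannot be anchored to a starting point, and the one earlier instance of the change gave no readable size. What remains is that both measured values in this assay sit at the limit.

On that basis compound 4 is expected to return 20000 nM, with an expected range from 8000 nM to 60000 nM, most likely reported only as a limit.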

Compound 4, half-maximal inhibitory concentration: 1610 nM
Compound 4: the middle estimate sits 12-fold (1.09 log units) above what was measured, outside the stated range (below it).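

In this assay compound 4 gives 1610 nM, but compound 3 has no reported result, so no step can be read between compound 3 and compound 4. Open is the size of the change from 2-hydroxyphenyl to 3-hydroxyphenyl on a carbonyl carbon on either core, because the pair of compound 1 and compound 2 gives no number either: the limit of > 10000 nM in this assay, at which 2 of the 4 values shown sit.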